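Nitro in place of hydrogen on the core of compound 2

This account rests on a few compounds, and the source may have more. Where it says the series, first, only, none or still open, it means among the compounds named here.

Of the compounds shown here, two sharing one core have been measured in an assay on isolated protein for inhibition of Alpha glucosidase (Homo sapiens), read by spectrophotometry, with stated times of 15 min and 30 min; on this read-out lower numbers stand for stronger inhibition and higher numbers for weaker inhibition. Compound 1 `CCOc1cc(/C=C2\SC(=O)NC2=O)ccc1OCN1C(=O)c2ccccc2C1=O` gives 29300 nM in this assay. Compound 2 `O=C1NC(=O)/C(=C/c2ccc(OCN3C(=O)c4ccccc4C3=O)cc2)S1` gives 25600 nM in this assay. Among the compounds with values here, the single step between them, a 1.1-fold lower number from compound 1 to compound 2 (0.06 log units; within the scatter), shows that hydrogen in place of ethoxy left the number within the scatter. Compound 2 stands at the lower of the two numbers, but its gap to compound 1 is within the scatter, so neither compound can be called the more potent. Compound 3 `O=C1NC(=O)/C(=C/c2ccc(OCN3C(=O)c4ccccc4C3=O)c([N+](=O)[O-])c2)S1` carries the change (nitro in place of hydrogen on an aromatic carbon), placed ortho to a large group and meta to a group of 8 heavy atoms. Within the data shown here, only the step between compound 1 and compound 2 bears on a change at this ring, and it stayed within the scatter. The expected step is therefore a 1.0-fold lower number from compound 2 to compound 3 (0.01 log units; within the scatter), nothing beyond the scatter. Compound 3 is expected to give 25000 nM in this assay, with a range from 10000 nM to 60000 nM.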

Compound 3, half-maximal inhibitory concentration: 22500 nM
Compound 3: middle estimate off by 1.1-fold (0.05 log units), on the high side; the measured number falls inside the stated range.
By their numbers in this assay, from the lowest: compounds 3, 2 and 1 (each within the scatter of the next).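

In this assay, nitro in place of hydrogen on this aromatic carbon gives a 1.1-fold lower number from compound 2 to compound 3 (0.06 log units; within the scatter), so a third kind of group here leaves the number within the scatter. Nitro in place of ethoxy at the same carbon gives a 1.3-fold lower number from compound 1 to compound 3 (0.11 log units; within the scatter), which is also within the scatter, so hydrogen, ethoxy and nitro cannot be told apart at this position in these three compounds. No measurement at hand offers an explanation for this flat result.

From the compounds shown here alone, whether an amine, a carboxylic acid or a longer chain on this carbon would shift the number beyond the scatter remains open. Also open, going by these compounds, is whether nitro on another carbon of this ring would read the same as it does here.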